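A Free Hydroxyl in Place of Acetate

The source may hold more compounds than are shown below. What is called first, only, known or untested is meant among the compounds shown, and "the series" means these compounds.

Compound 3 `C=C1CC[C@@]2(C[C@@H]1OC(C)=O)[C@@H](C(=O)O)CC[C@H]2C(C)C` was examined in an ADME assay on HEK293 cells for inhibition of 11-beta-hydroxysteroid dehydrogenase type 2 (Homo sapiens), read by HTRF, with a stated time of 2 h, in the presence of a further agent that is not named here (on this read-out lower numbers stand for stronger inhibition and higher numbers for weaker inhibition), together with compound 1 `CC(=O)O[C@@H]1C[C@@](C)(O)CC[C@]12[C@@H](C(=O)O)CC[C@H]2C(C)C` and compound 2 `C=C1CC[C@@]2(C(OC)[C@@H]1O)[C@@H](C(=O)O)CC[C@H]2C(C)C`. In this assay compound 1 returns > 500000 nM, which is a limit of the assay rather than a number. Compound 2 likewise returns > 500000 nM, again only a limit. Compound 3 itself gives > 500000 nM, also a limit and not a measured number. All three values therefore sit at the limit of > 500000 nM in this assay, at which 3 of the 3 values shown sit, so compound 3 stands nowhere in particular among them, and no order can be read from the figures.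

Compound 4 `C=C1CC[C@@]2(C[C@@H]1O)[C@@H](C(=O)O)CC[C@H]2C(C)C` differs from compound 3 by hydrogen in place of acetyl on an oxygen on a saturated carbon. Within the data shown here, no step between two measured compounds is available, so the expectation for compound 4 rests only on the three limits. The step is expected to be a step that the limit leaves unreadable from compound 3 to compound 4, that is, none beyond the scatter. Compound 4 is estimated at 700000 nM, within a range from 300000 nM to 2000000 nM, and is most likely to be reported once more as a limit.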

Compound 4, half-maximal inhibitory concentration: > 500000 nM
Compound 4: a limit, no number (the forecaster's own chance of this, stated with the estimate: 85%); the middle value is on the limit's open side.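

Neither the step from compound 3 to compound 4 nor the step from compound 2 to compound 4 can be read, since compound 4 also gives only a limit in this assay and not a number: the limit of > 500000 nM in this assay, at which 4 of the 4 values shown sit.

The compounds shown leave open whether hydroxy in place of acetoxy alters inhibition at all.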